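Thiazolidinone series: cytotoxicity on Vero cells

The compounds below may be only part of what the source reports. "The series", "measured", "known", "first", "only" and "open" are said of these compounds alone.

Measured so far:
- compound 1 `O=C1CSC(c2c(Cl)cccc2Cl)N1CCN1CCCCC1`: 100%
- compound 2 `O=C1CSC(c2ccc(O)cc2)N1CCN1CCCCC1`: 100%

In an ADME assay on Vero cells (Chlorocebus sabaeus) for cytotoxicity, read by neutral red uptake, tested at 12.3 ug/mL (a higher number here means a weaker effect of the compound at the concentration tested, a lower number a stronger effect), compound 1 gives 100%. In this assay compound 2 gives 100%. Compound 2 thus stands level with compound 1 at the digits shown; the two values lie within the scatter of each other, so no order between them can be read. Among the measured compounds shown here, no step between the measured compounds is counted here, which leaves nothing beyond these two equal read-outs to build on.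

Compound 3 `O=C1CSC(c2ccc(Cl)cc2)N1CCN1CCCCC1` is not yet measured. It differs from compound 2 in one place: chloro in place of hydroxy on an aromatic carbon.

With both measured compounds sitting at the same full read-out, no change beyond the scatter is expected for this step in this assay. Compound 3 is expected to give 100%, with a range from 85% to 100%. The step from compound 2 to compound 3 is expected to be no change at the digits printed from compound 2 to compound 3 (within the scatter).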

Compound 3, a percentage reported as activity, at one concentration (the size of the read-out at that concentration, not a potency): 90%
For compound 3 the middle estimate is 10 percentage points above the measured one; the range from low to high includes it.
By their numbers in this assay, from the lowest: compounds 3, 1 and 2 (each within the scatter of the next).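

In this assay, among the compounds shown here, going from 4-hydroxyphenyl to 4-chlorophenyl gives a number 10 percentage points lower from compound 2 to compound 3 (within the scatter) and is the first one-place comparison. At this position, on an aromatic carbon para to a large group, a hydroxy with its hydrogen-bond donor and acceptor can give way to a chloro with neither, and the read-out stays within the scatter. No measured evidence bears on this step, so the result carries no explanation.

From the compounds shown here alone, whether an amine, a carboxylic acid or a methoxy group at this same carbon would also stay within the scatter of compound 2 remains open. The compounds shown also do not tell whether a one-place change to chloro or hydroxy at another carbon of the aromatic ring would read the same way.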